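Extending the Amide Substituent of a Hydroxamic Acid Analogue

The source may report more compounds than this note shows. Statements on the series, on what has been measured and on what is new or still open speak of the compounds shown alone.

Of the compounds shown here, two from this series have been measured in a functional assay on NCI-H1975 cells (Homo sapiens) for inhibition, with a stated time of 72 h; a higher number here means a weaker inhibitor of growth, a lower number a stronger inhibitor of growth. Compound 1 `COC(=O)c1ccc(CN(C)C(=O)c2cc(C(C)C)c(O)cc2O)cc1` gives 3500 nM in this assay, whereas compound 2 `CN(Cc1ccc(C(=O)NO)cc1)C(=O)c1cc(Cl)c(O)cc1O` gives 68800 nM. Compound 2 therefore stands at the highest number of the two, and its nearest neighbour, compound 1, sits far enough away that the gap lies beyond the usual scatter; the two differ in more than one place, so no single step between them is shown.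

Compound 3 `CCCCN(Cc1ccc(C(=O)NO)cc1)C(=O)c1cc(Cl)c(O)cc1O` has not yet been measured. It differs from compound 2 in one place: propyl in place of hydrogen on a saturated chain carbon bound to an amide-type nitrogen. Within the data shown here, no pair of measured compounds differing in one place is available, so there is no measured step of this kind to lean on. In the absence of such a step, a modest change in this assay is expected, most likely within the scatter or only slightly beyond it, with no firm direction. The expected step in this assay comes to a 1.7-fold lower number from compound 2 to compound 3 (0.24 log units; within the scatter). Compound 3 is accordingly estimated to give 40000 nM, with a range from 12000 nM to 130000 nM.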

Compound 3, concentration for 50% growth inhibition: 66400 nM
The estimate for compound 3 lay 1.7-fold (0.22 log units) below the measured number; measured number inside the range.
By their numbers in this assay, from the lowest: compound 1; then compounds 3 and 2 (each within the scatter of the next).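

In this assay, the first step measured at this position, a 1.0-fold lower number from compound 2 to compound 3 (0.02 log units; within the scatter), lies within the scatter, so compound 2 and compound 3 cannot be told apart. Read one bond further out, the same difference is methyl to butyl, and this single comparison shows that, on this core, replacing methyl with butyl gives neither a measurable gain nor a measurable loss in growth inhibition. No measurement available here accounts for this flat result.

Only methyl and butyl are shown at this position, so it remains open whether the result holds for a longer chain such as octyl, for a benzyl group, or for a chain ending in an amine or a carboxylic acid. Compound 1 differs from compound 2 in more than one place, which leaves the separate contributions of the hydroxamic acid against the methyl ester, and of chlorine against isopropyl, unresolved; a compound changing only one of these would be needed to read either of them.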